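From Compound 1 to Compound 3

The source may report more compounds than this note shows. Statements on the series, on what has been measured and on what is new or still open speak of the compounds shown alone.

Compound 1, `Cn1ccc(-c2cccc3c2CCC3c2ncc[nH]2)n1`: > 1300 nM
Compound 2, `Cc1c(OCC2=NCCN2)ccc(Cl)c1NS(C)(=O)=O`: 25 nM

In a functional assay on CHO cells for agonist activity at Alpha-1A adrenergic receptor (Homo sapiens), read by FLIPR and calcium flux (a higher number here means that more compound is needed for the effect, a lower number that less compound is needed), compound 1 gives only a limit, > 1300 nM, so its true potency is not known, as the limit of > 1300 nM in this assay, at which 1 of the 2 values shown sits, records. Among the compounds with values here, compound 2, built on a different core, gives 25 nM in this assay, and since the two structures share no single change, the pair shows only that the two values are far apart.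

Compound 3, `CCS(=O)(=O)Nc1cccc2c1CCC2c1ncc[nH]1`, keeps the core of compound 1 and differs in one place: (ethylsulfonyl)amino in place of 1-methyl-1H-pyrazol-3-yl on an aromatic carbon.

Within the data shown here, no measured step covers this change. Because compound 1 sits at a limit (the limit of > 1300 nM in this assay, at which 1 of the 2 values shown sits), any measured number for compound 3 would already be a gain beyond the scatter. Compound 3 is expected to give about 300 nM in this assay, within 50 nM to 3000 nM, an estimated step of an at least 4.3-fold lower number from compound 1 to compound 3 (0.63 log units; beyond the scatter) toward lower values, though a second limit remains possible.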

Compound 3, half-maximal effective concentration: 32 nM
Estimate against measurement, compound 3: 9.4-fold (0.97 log units) above; measured number outside the range, below it.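

On the aromatic carbon ortho to a fused ring, the choice of group matters greatly in this assay: on the shared core, (ethylsulfonyl)amino in place of 1-methyl-1H-pyrazol-3-yl gives an at least 40-fold lower number from compound 1 to compound 3 (1.60 log units; beyond the scatter). The two groups match in their counts of heavy atoms and hydrogen-bond acceptors, but the entering group has no ring and adds a hydrogen-bond donor, so a large step can come with no change in those two counts. Compound 1 stands at a limit, so this step gives a minimum and not an exact size: the limit of > 1300 nM in this assay, at which 1 of the 3 values shown sits.

The compounds shown do not separate the contribution of the sulfonyl part from that of the hydrogen on its nitrogen. They also leave open how a longer chain in place of ethyl, or a plain amine or a carboxylic acid on this carbon, would compare.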